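Thiophen-2-yl in place of benzofuran-2-yl on a shared core

This account rests on a few compounds, and the source may have more. Where it says the series, first, only, none or still open, it means among the compounds named here.

Compound 1 `CN(C)c1ncnc2c1c(-c1cc3ccccc3o1)cn2[C@@H]1O[C@H](CO)[C@@H](O)[C@H]1O` — > 20000 nM
Compound 2 `Cc1ncnc2c1c(-c1cc3ccccc3o1)cn2[C@@H]1O[C@H](CO)[C@@H](O)[C@H]1O` — > 20000 nM

In a functional assay on HCT-116 cells (Homo sapiens), read by MTT assay, with a stated time of 72 h (on this read-out lower numbers stand for stronger inhibition and higher numbers for weaker inhibition), compound 1 gives only a limit, > 20000 nM. Compound 2 likewise returns a limit in this assay, > 20000 nM. Between them lies a step that the two limits leave unreadable from compound 1 to compound 2, and both values sit at the limit of > 20000 nM in this assay, at which 2 of the 2 values shown sit. Compound 3 `CN(C)c1ncnc2c1c(-c1cccs1)cn2[C@@H]1O[C@H](CO)[C@@H](O)[C@H]1O` differs from compound 1 in one place: thiophen-2-yl in place of 1-benzofuran-2-yl on an aromatic carbon. Going by the values given here, no measured step bears on this change, so nothing beyond the scatter is expected in this assay. Compound 3 is therefore expected to give 20000 nM (range 5000 nM to 60000 nM). That estimate means an expected step of a number no higher from compound 1 to compound 3 (the limit leaves the size open), most likely again reported only as a limit.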

Compound 3, half-maximal inhibitory concentration: > 20000 nM
Compound 3 ended at the assay's limit (the forecaster's own chance of this, stated with the estimate: 75%); the middle value sits exactly at the limit.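

Compound 1 and compound 3 both give only a limit, so no step can be read between them in this assay: the limit of > 20000 nM in this assay, at which 3 of the 3 values shown sit.

The compounds shown leave open whether thiophen-2-yl and 1-benzofuran-2-yl differ at all in this read-out.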